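Amine substituent on the core: saturated ring to phenyl

The source may hold more compounds than are shown below. What is called first, only, known or untested is meant among the compounds shown, and "the series" means these compounds.

Within the data shown here, compound 2 `CC1CCC(Nc2nc(C(F)(F)F)ccc2CNC(=O)C(C)c2ccc(NS(C)(=O)=O)c(F)c2)CC1` gives 27.2 nM in a functional assay on CHO-K1 cells for antagonist activity at transient receptor potential cation channel subfamily V member 1 (Homo sapiens), read by FLIPR (a lower number here means a stronger inhibitor, a higher number a weaker inhibitor), the higher of the two numbers so far; compound 1 `CC(C(=O)NCc1ccc(C(F)(F)F)nc1NC1CCCCC1)c1ccc(NS(C)(=O)=O)c(F)c1` gives 20.4 nM in this assay, and the two lie within the scatter of each other. Compound 3 `CC(C(=O)NCc1ccc(C(F)(F)F)nc1Nc1ccccc1)c1ccc(NS(C)(=O)=O)c(F)c1` carries phenyl in place of 4-methylcyclohexyl on a nitrogen on an aromatic ring. Among the measured compounds shown here, the only measured step, a 1.3-fold higher number from compound 1 to compound 2 (0.12 log units; within the scatter), changes the saturated ring itself rather than exchanging it, so no measured step bears on the change to compound 3. In this assay compound 3 is therefore expected to give 45 nM, with a range of 12 nM to 170 nM. The expected step of a 1.7-fold higher number from compound 2 to compound 3 (0.22 log units; within the scatter) is thus small, with a wide range.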

Compound 3, inhibition constant: 59.6 nM
For compound 3 the middle estimate is 1.3-fold (0.12 log units) below the measured one; the measured number falls inside the stated range.
By their numbers in this assay, from the lowest: compounds 1 and 2 (each within the scatter of the next); then compound 3.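

In this assay, among these compounds, phenyl in place of the saturated ring is the first change at this nitrogen to go beyond the scatter, with a 2.2-fold higher number from compound 2 to compound 3 (0.34 log units; beyond the scatter) and a 2.9-fold higher number from compound 1 to compound 3 (0.47 log units; beyond the scatter). Both steps are modest and run the same way, so anilino compound 3 is a weaker inhibitor than either compound 1 or compound 2, yet the aromatic ring is accepted here without a large loss. Nothing at hand explains this difference.

Open, going by these compounds, is how a substituted phenyl, such as 4-fluorophenyl, or a pyridyl ring would compare with phenyl. Open too, on these data alone, is how a smaller saturated ring, such as cyclopentyl, would compare with cyclohexyl.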